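The source may hold more compounds than are shown below. What is called first, only, known or untested is meant among the compounds shown, and "the series" means these compounds.

Measured in a functional assay, with a stated time of 150 min; a higher number here means a weaker inhibitor, a lower number a stronger inhibitor:
- compound 1, `CCOC(=O)c1cnn(-c2nc(-c3ccc(OC)cc3)c(C#N)c(=O)n2C)c1N`: 79 ug/mL
- compound 2, `CCOC(=O)c1cnn(-c2nc(-c3ccco3)c(C#N)c(=O)n2C)c1N`: 108 ug/mL
- compound 3, `CCOC(=O)c1cnn(-c2nc(-c3cccs3)c(C#N)c(=O)n2C)c1N`: 98 ug/mL

Compound 3 stands second highest of the three numbers; its nearest neighbour is compound 2, a 1.1-fold lower number from compound 2 to compound 3 (0.04 log units; within the scatter), and its furthest is compound 1, a 1.2-fold higher number from compound 1 to compound 3 (0.09 log units; within the scatter). All three values sit within the scatter of one another, so none of the three can be called the strongest or weakest.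

Compound 4, `CCOC(=O)c1cnn(-c2nc(-c3ccc(Cl)cc3)c(C#N)c(=O)n2C)c1N`, has not yet been measured. The change from compound 3 is 4-chlorophenyl in place of thiophen-2-yl on an aromatic carbon. Among the measured compounds shown here, the one measured step that bears on it most directly is the exchange of a six-membered aryl for this five-membered ring, a 1.2-fold higher number from compound 1 to compound 3 (0.09 log units; within the scatter), which runs in the opposite direction and lies within the scatter; the exchange between the two five-membered rings, a 1.1-fold lower number from compound 2 to compound 3 (0.04 log units; within the scatter), was likewise within the scatter. For the measured compounds named here, no measured compound carries a 4-chlorophenyl group, so the effect of the chlorine itself is unknown. From these steps compound 4 is expected to show no change beyond the scatter, if anything a slightly lower number, a 1.2-fold lower number from compound 3 to compound 4 (0.06 log units; within the scatter). Compound 4 is therefore estimated at 85 ug/mL, with a range from 45 ug/mL to 160 ug/mL.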

Compound 4, half-maximal inhibitory concentration: 87 ug/mL
For compound 4 the middle estimate is 1.0-fold (0.01 log units) below the measured one; the range from low to high includes it.
By their numbers in this assay, from the lowest: compounds 1, 4, 3 and 2 (each within the scatter of the next).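

In this assay, the position ortho to a cyano group also accepts a 4-chlorophenyl group without leaving the scatter of the two five-membered rings, whether set against thiophen-2-yl (a 1.1-fold lower number from compound 3 to compound 4 (0.05 log units; within the scatter)) or against furan-2-yl (a 1.2-fold lower number from compound 2 to compound 4 (0.09 log units; within the scatter)). Unlike the earlier steps, which all replaced one ring with another, the pair of compound 1 and compound 4 keeps the six-membered aromatic ring and exchanges only methoxy for chloro on it, and this step also stays within the scatter (a 1.1-fold higher number from compound 1 to compound 4 (0.04 log units; within the scatter)). Nothing measured here offers an explanation for why all of these steps are so small.

The compounds shown leave open whether any group at this position can move the number beyond the scatter, as all of them carry an aromatic ring there, and an amine, a carboxylic acid or a longer alkyl chain in its place would be a much larger change. Also open, from the compounds shown here alone, is whether changes elsewhere on the shared core, such as replacing the nitrile or the ethyl ester, would matter more than the group at this position.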